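From compound 2 to compound 4: chloro for trifluoromethyl

The compounds below may be only part of what the source reports. "The series", "measured", "known", "first", "only" and "open" are said of these compounds alone.

Measured compounds and their values:
compound 1 `Cc1cccc(Cn2c(OC3CCN(C(=O)c4ccco4)CC3)nc3ccccc32)c1`: 68.3%
compound 2 `Cc1cccc(Cn2c(CN3CCN(C(=O)c4ccc(C(F)(F)F)cc4)CC3)nc3ccccc32)c1`: 22.9%
compound 3 `CC(C)CCn1c(CN2CCN(C(=O)c3ccco3)CC2)nc2ccccc21`: 42.1%

In an assay on isolated protein for inhibition of aldehyde dehydrogenase 1A1 (Homo sapiens), read by spectrophotometry, tested at 10 uM (on this read-out lower numbers stand for less inhibition and higher numbers for more inhibition at the one concentration tested (going by the name of the read-out)), compound 2 gives 22.9%, the lowest of the three numbers; compound 3 sits beyond the scatter above it, and compound 1 further still. Compound 4 `Cc1cccc(Cn2c(CN3CCN(C(=O)c4ccc(Cl)cc4)CC3)nc3ccccc32)c1` differs from compound 2 in a single place: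

chloro in place of trifluoromethyl on an aromatic carbon

Among the compounds with values here, no measured pair in the set carries this change, so nothing here shows what it does. The group that leaves is counted larger than the one that enters, but the two are not compared anywhere among the measured compounds. The expectation is a step from compound 2 to compound 4 of about a number 7.1 percentage points higher from compound 2 to compound 4 (within the scatter), which may well stay within the scatter. Compound 4 is estimated at 30%, with a range from 10% to 55%.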

Compound 4, a percentage reported as inhibition, at one concentration (the size of the read-out at that concentration, not a potency): 23.2%
For compound 4 the middle estimate is 6.8 percentage points above the measured one; low and high end bracket the measured number.
By their numbers in this assay, from the lowest: compounds 2 and 4 (each within the scatter of the next); then compound 3; then compound 1.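

In this assay, within the data shown here, chloro in place of trifluoromethyl on this aromatic carbon, para to a large group, gives a number 0.3 percentage points higher from compound 2 to compound 4 (within the scatter) and is the first reading of this position. The two groups are not told apart here, although chloro has fewer heavy atoms, so this swap leaves the read-out without a measurable change. No measurement available bears on why the two groups read alike.

Left open is whether an amine, a carboxylic acid or a methoxy group on this aromatic carbon would read differently from chloro and trifluoromethyl.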